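Benzyl on the amide of compound 1

This account rests on a few compounds, and the source may have more. Where it says the series, first, only, none or still open, it means among the compounds named here.

- compound 1 `O=C(NCc1ccccc1)c1nc(-c2ccccc2)[nH]c1C(=O)O` | "not determined" (no result reported)
- compound 2 `O=C(O)c1[nH]c(-c2ccccc2)nc1C(=O)N1CCOCC1` | > 200000 nM (a limit)

In a functional assay on PC-3 cells (Homo sapiens) for inhibition (a lower number here means a stronger inhibitor of growth, a higher number a weaker inhibitor of growth), compound 1 has no number and stands as "not determined" (no result reported). For the measured compounds named here, the only reading belongs to compound 2, and it is a limit: the limit of > 200000 nM in this assay, at which 1 of the 2 values shown sits. Compound 3 `O=C(O)c1[nH]c(-c2ccccc2)nc1C(=O)N(Cc1ccccc1)Cc1ccccc1` is the next structure. Benzyl replaces hydrogen on an amide-type nitrogen in benzyl in place of hydrogen on an amide-type nitrogen. Compound 1 offers no number to step from. Only a small step towards stronger growth inhibition is expected in this assay, and another limit would not be surprising. Compound 3 is estimated at 120000 nM, with an expected range from 30000 nM to 300000 nM.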

Compound 3, concentration for 50% growth inhibition: 21000 nM
The estimate for compound 3 lay 5.7-fold (0.76 log units) above the measured number; the measured number lies below the stated range.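

In this assay, for the compounds shown here, compound 3 gives 21000 nM, while compound 1 stands as "not determined" (no result reported), so no step between compound 1 and compound 3 can be read. From the compounds shown here alone, what the added benzyl on the amide-type nitrogen does to growth inhibition in this assay remains open.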